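Methoxy for methyl on the aryl ring of compound 3

The compounds below may be only part of what the source reports. "The series", "measured", "known", "first", "only" and "open" are said of these compounds alone.

Measured compounds:
- compound 1, `CC(c1ccc(-c2ccccc2)c(F)c1)c1nnc2n1N=C(c1ccc(C(F)(F)F)cc1)CS2`, 4300 nM
- compound 2, `CC(c1ccc(-c2ccccc2)c(F)c1)c1nnc2n1N=C(c1ccccc1)CS2`, 7400 nM
- compound 3, `Cc1ccc(C2=Nn3c(nnc3C(C)c3ccc(-c4ccccc4)c(F)c3)SC2)cc1`, 5000 nM

All three were tested in a functional assay on MCF7 cells (Homo sapiens) for inhibition, read by sulforhodamine B assay, with a stated time of 72 h; a higher number here means a weaker inhibitor, a lower number a stronger inhibitor. Compound 3 stands second highest of the three numbers; its nearest neighbour is compound 1, and a 1.2-fold higher number from compound 1 to compound 3 (0.07 log units; within the scatter). Its furthest neighbour is compound 2, and a 1.5-fold lower number from compound 2 to compound 3 (0.17 log units; within the scatter). Compound 1 and compound 2 sit close as well, since a 1.7-fold higher number from compound 1 to compound 2 (0.24 log units; within the scatter). Every step among these three therefore lies within the scatter, so no compound can be called stronger or weaker than another on this evidence.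

Compound 4, `COc1ccc(C2=Nn3c(nnc3C(C)c3ccc(-c4ccccc4)c(F)c3)SC2)cc1`, has not yet been measured in this assay. Relative to compound 3 the change is methoxy in place of methyl on an aromatic carbon. The measured steps that bear on this are the ones that swap the group at the same place: trifluoromethyl, hydrogen and methyl all gave numbers within the scatter of each other. Nothing suggests that putting a methoxy there would move the number beyond the scatter in either direction. Compound 4 is therefore expected to give about 5000 nM in this assay, in a range from 2300 nM to 11000 nM. The expected step is no change at the digits printed from compound 3 to compound 4 (within the scatter), which is estimated to be no change beyond the scatter.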

Compound 4, half-maximal inhibitory concentration: 2600 nM
Estimate against measurement, compound 4: 1.9-fold (0.28 log units) above; the range from low to high includes it.
By their numbers in this assay, from the lowest: compounds 4, 1, 3 and 2 (each within the scatter of the next, the first and the last beyond it).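

Among the first three compounds, no group on this aromatic ring could be told apart from another, but methoxy gives the first step at this place that clears the scatter in this assay: a 2.8-fold lower number from compound 2 to compound 4 (0.45 log units; beyond the scatter). That step is modest and holds against hydrogen only, since a 1.9-fold lower number from compound 3 to compound 4 (0.28 log units; within the scatter) and a 1.7-fold lower number from compound 1 to compound 4 (0.22 log units; within the scatter) both remain within the scatter, so compound 4 cannot be separated from the methyl or trifluoromethyl compounds. Nothing available here explains why methoxy parts from hydrogen in this way.

The compounds shown leave open whether the oxygen itself matters, which a hydroxyl group, an ethoxy group or a dimethylamino group at the same place could begin to test against methoxy and methyl. They also leave open how a larger or charged group, such as a morpholine ring or a carboxylic acid, would fare on this ring, and whether methoxy would give a similar number at another place on it.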